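The compounds below may be only part of what the source reports. "The series", "measured", "known", "first", "only" and "open" are said of these compounds alone.

Measured so far in a functional assay on DLD-1 cells (Homo sapiens) for antiproliferative activity, read by CellTiter-Glo, with a stated time of 72 h; on this read-out lower numbers stand for stronger inhibition and higher numbers for weaker inhibition:
- compound 1 `Cc1c(C)c(S(=O)(=O)N2CCC(N3CCC(C)CC3)CC2)c(C)c2c1OC(C)(C)C2`: 1.2 nM
- compound 2 `CC1CCN(C2CCN(S(=O)(=O)c3ccc(-c4ccccc4)cc3)CC2)CC1`: 258 nM

In this assay compound 2 stands at the higher of the two numbers; the gap to compound 1, which gives 1.2 nM, lies well beyond the scatter.

Compound 3 `COc1ccc(-c2ccc(S(=O)(=O)N3CCC(N4CCC(C)CC4)CC3)cc2)cc1` differs from compound 2 by methoxy in place of hydrogen on an aromatic carbon of the six-membered aromatic ring of carbon only, para to a large group. Among the measured compounds shown here, no measured pair shows this change, so the size of the step is unknown; the expectation is a step from compound 2 to compound 3 of a 1.4-fold lower number from compound 2 to compound 3 (0.16 log units; within the scatter), not beyond the scatter. Compound 3 is estimated at 180 nM, with a range from 60 nM to 600 nM.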

Compound 3, half-maximal inhibitory concentration: 263 nM
Compound 3: middle estimate off by 1.5-fold (0.16 log units), on the low side; the range from low to high includes it.
By their numbers in this assay, from the lowest: compound 1; then compounds 2 and 3 (each within the scatter of the next).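

Methoxy in place of hydrogen on an aromatic carbon, para to a large group, gives a 1.0-fold higher number from compound 2 to compound 3 (0.01 log units; within the scatter) in this assay. Among the compounds shown here, this position therefore accepts methoxy with no step that can be told from the scatter. Nothing available explains this result.

On these data alone, whether an amine or a carboxylic acid at this position would also stay within the scatter of compound 2 remains open. Also open is which of the several differences between compound 1 and compounds 2 and 3 accounts for their gap.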